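The source may hold more compounds than are shown below. What is called first, only, known or untested is meant among the compounds shown, and "the series" means these compounds.

Measured in an assay on isolated protein for inhibition of methionine--tRNA ligase, cytoplasmic (Homo sapiens); a lower number here means a stronger inhibitor, a higher number a weaker inhibitor:
compound 1 `NC(=O)c1cc(-c2ccc(-c3ccc(Cl)cc3Cl)cc2)n(-c2ccccn2)n1`: > 100000 nM
compound 2 `O=C(O)c1cc(-c2ccc(-c3ccccc3)cc2)n(-c2ccc(Cl)cc2Cl)n1`: 44300 nM
compound 3 `O=C(O)c1cc(-c2ccc(-c3ccc(Cl)cc3Cl)cc2)n(Cc2ccncc2)n1`: 26200 nM

The value of compound 1 is a limit of the assay, not a number. Among the two numbers, compound 2 stands alongside compound 3; the gap between them is within the usual scatter, so no order is read from it. Compound 4 `O=C(O)c1cccc(-c2ccc(-c3cc(C(=O)O)nn3-c3ccc(Cl)cc3Cl)cc2)c1` differs from compound 2 by carboxy in place of hydrogen on an aromatic carbon. Among the compounds with values here, no step between measured compounds covers this change, so the expectation rests on compound 2 alone: a small shift in this assay, with the expected step of a 1.5-fold lower number from compound 2 to compound 4 (0.17 log units; within the scatter) lying within the scatter. Compound 4 is estimated at 30000 nM, with a range from 8000 nM to 110000 nM.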

Compound 4, half-maximal inhibitory concentration: 40900 nM
Estimate against measurement, compound 4: 1.4-fold (0.13 log units) below; measured number inside the range.
By their numbers in this assay, from the lowest: compounds 3, 4 and 2 (each within the scatter of the next). At a limit, above all of these: compound 1.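

In this assay, exchanging phenyl for 3-carboxyphenyl gives a 1.1-fold lower number from compound 2 to compound 4 (0.03 log units; within the scatter), so this position takes a carboxy group on an aromatic carbon with no readable change. Within the data shown here, none of the earlier compounds varied this ring. Both compounds sit in the upper part of the readable range, which ends at a ceiling: the limit of > 100000 nM in this assay, at which 1 of the 4 values shown sits.

Going by these compounds, whether an amine or a hydroxymethyl group at this place would shift the number stays open. Also open, on these data alone, is whether any group here can bring the series well clear of this level.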